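Swapping the aryl on a triazole oxime ether

The compounds below may be only part of what the source reports. "The series", "measured", "known", "first", "only" and "open" are said of these compounds alone.

Compound 1 `COc1ccc([C@@H]2C/C(=N/OCc3cn(-c4cccc(CO)c4)nn3)c3cc(CC=C(C)C)c(OC)cc3O2)cc1` is one of two compounds tested in a functional assay on PC-3 cells (Homo sapiens) for inhibition, read by sulforhodamine B assay, with a stated time of 48 h, tested at 50 uM; a higher number here means more inhibition of growth at the concentration tested, a lower number less inhibition of growth. In that assay compound 1 gives 34%, the lower of the two numbers seen. Within the data shown here, compound 2 `COc1cc2c(cc1CC1OC1(C)C)C(=O)C[C@@H](c1ccc(O)cc1)O2`, built on a different core, gives 92% in this assay, a number well beyond the scatter above compound 1, but no single-point step links the two, so their values are only to be read side by side.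

Compound 3 `COc1ccc([C@@H]2C/C(=N/OCc3cn(-c4ccc(NC(C)=O)cc4)nn3)c3cc(CC=C(C)C)c(OC)cc3O2)cc1` shares the core of compound 1 and differs in one place: 4-acetamidophenyl in place of 3-(hydroxymethyl)phenyl on an aromatic nitrogen. Among the measured compounds shown here, no measured step of this kind is available to set the size of the change. Since the change touches only the aryl on the triazole, the expected step is a number 2 percentage points higher from compound 1 to compound 3 (within the scatter), of small size. Compound 3 is therefore estimated to give 36% in this assay, with a range from 15% to 60%.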

Compound 3, percent growth inhibition at one concentration: 2%
For compound 3 the middle estimate is 34 percentage points above the measured one, and the stated range ends above it.
By their numbers in this assay, from the lowest: compound 3; then compound 1; then compound 2.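

In this assay, putting 4-acetamidophenyl in place of 3-(hydroxymethyl)phenyl on the aromatic nitrogen gives a number 32 percentage points lower from compound 1 to compound 3 (beyond the scatter), so with the shared core held constant, this position clearly responds to the choice of aryl. The comparison of compound 1 with compound 2 could not show this, as those two compounds have different cores, and the change here is one of substituent identity without any change in the printed count of hydrogen-bond donors or acceptors. Nothing available explains the size or direction of the step.

The two aryl groups differ in both the substituent and its numbered location on the phenyl ring, so the compounds shown do not separate these two contributions. On these data alone, it also remains open how an aryl carrying an amine or a carboxylic acid would behave at this position.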